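The source may hold more compounds than are shown below. What is called first, only, known or untested is meant among the compounds shown, and "the series" means these compounds.

Measured in a functional assay on cells (Homo sapiens) for cytotoxicity, read by MTT assay, with a stated time of 72 h; a higher number here means a weaker inhibitor, a lower number a stronger inhibitor:
compound 1 `CC(C)(C)c1nc2ccccc2n1C(=O)c1cccc2ccccc12`: > 10000 nM
compound 2 `COc1ccc(-c2nc3ccccc3n2C(=O)c2cccc3ccccc23)cc1`: > 10000 nM

Compound 2 stands at > 10000 nM, which is a limit of the assay and not a number. Compound 1 also gives only a limit, > 10000 nM.

Compound 3 `O=C(c1cccc2ccccc12)n1c(C2CCC2)nc2ccccc21` differs from compound 2 by cyclobutyl in place of 4-methoxyphenyl on an aromatic carbon. The group changes on an aromatic carbon of a five-membered aromatic ring with 2 nitrogen, with cyclobutyl in place of 4-methoxyphenyl.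

Going by the values given here, one measured step bears on this change, a step that the two limits leave unreadable from compound 1 to compound 2, which also exchanges the group on an aromatic carbon. Both its ends rest on (the limit of > 10000 nM in this assay, at which 2 of the 2 values shown sit), so it gives no size to carry over. In this assay, no step beyond the scatter is expected, and the estimated step is a step that the limit leaves unreadable from compound 2 to compound 3. A reading at the same limit is the likeliest result. Compound 3 is estimated at 12000 nM, with an expected range from 4000 nM to 30000 nM.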

Compound 3, half-maximal inhibitory concentration: > 10000 nM
Compound 3: a limit, no number (the forecaster's own chance of this, stated with the estimate: 80%); the middle value does not contradict the limit.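

In this assay compound 3 gives only a limit and not a number, as do compound 1 and compound 2, so no step among the three can be read: the limit of > 10000 nM in this assay, at which 3 of the 3 values shown sit.

The compounds shown leave open whether any group at this place on the shared core gives a readable value, and how large a step between these groups would be.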